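This account rests on a few compounds, and the source may have more. Where it says the series, first, only, none or still open, it means among the compounds named here.

Values from a functional assay on HT-1080 cells (Homo sapiens) for cytotoxicity, read by MTT assay, with a stated time of 72 h (a higher number here means a weaker inhibitor, a lower number a stronger inhibitor), follow.

Compound 1 `COc1cccc(/C=C2\CCC/C(=C\c3ccc(O)c(O)c3)C2=O)c1OC` gives 4700 nM
Compound 2 `COc1ccc(/C=C2\CCC/C(=C\c3ccc(Br)cc3)C2=O)cc1OC` gives 4300 nM

Within the data shown here, compound 2 stands within the scatter of compound 1, so these two numbers set no order between the compounds. Compound 3 `COc1ccc(/C=C2\CCC/C(=C\c3ccc(O)cc3)C2=O)cc1OC` keeps the core of compound 2 and makes one change, hydroxy in place of bromo on an aromatic carbon. Among the measured compounds shown here, no measured pair differs in one place only, so this change has no direct precedent in this assay here. Compound 1 carries hydroxy groups and gives 4700 nM in this test, though it differs from compound 2 in more than one place. Compound 2, with its bromo, gives 4300 nM in the same test. No step beyond the scatter is therefore expected, in either direction. The estimated step is small (a 1.1-fold lower number from compound 2 to compound 3 (0.03 log units; within the scatter)) and is expected to stay within the scatter. For compound 3 the expected value is 4000 nM with an estimated range from 1500 nM to 10000 nM in all.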

Compound 3, half-maximal inhibitory concentration: 16800 nM
Beside the measured number, compound 3's estimate is 4.2-fold (0.62 log units) below it; the whole stated range lies below it.
By their numbers in this assay, from the lowest: compounds 2 and 1 (each within the scatter of the next); then compound 3.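

In this assay, among these compounds, the change from 4-bromophenyl to 4-hydroxyphenyl gives a 3.9-fold higher number from compound 2 to compound 3 (0.59 log units; beyond the scatter) and is the only change here that can be read at a single place, since compound 1 and compound 2 differ in more than one. It shows that this position, on an aromatic carbon para to a large group, is not indifferent to what it carries: with the rest of the structure held constant, hydroxy in place of bromo gives a higher number, meaning a weaker inhibitor. Nothing available accounts for this step.

The compounds shown leave open where an amine, a carboxylic acid or a fluoro group at this position would fall relative to bromo and hydroxy. They also leave open whether the same exchange would give a similar step with different groups on the other aromatic ring.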